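From 2-fluorobenzyl to 3-methoxybenzyl: a step behind a limit

The compounds below may be only part of what the source reports. "The series", "measured", "known", "first", "only" and "open" are said of these compounds alone.

Compound 1 `COc1ccc(Nc2ncnc3ccc(-c4ccc(S(=O)(=O)N5CCOCC5)cc4)cc23)cc1Cl`: > 15000 nM (a limit)
Compound 2 `O=S(=O)(c1ccc(-c2ccc3ncnc(Nc4ccc(OCc5cccc(Br)c5)c(Cl)c4)c3c2)cc1)N1CCOCC1`: > 15000 nM (a limit)
Compound 3 `O=S(=O)(c1ccc(-c2ccc3ncnc(Nc4ccc(OCc5ccccc5F)c(Cl)c4)c3c2)cc1)N1CCOCC1`: > 15000 nM (a limit)

These compounds were tested in an ADME assay on HepG2 cells (Homo sapiens) for cytotoxicity, read by MTT assay, with a stated time of 48 h; a higher number here means a weaker inhibitor, a lower number a stronger inhibitor. Compound 3 gives > 15000 nM, which is a limit of the assay and not a number. It therefore has no measured value of its own, and it shares its position with the other two compounds: the limit of > 15000 nM in this assay, at which 3 of the 3 values shown sit.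

Compound 4 `COc1cccc(COc2ccc(Nc3ncnc4ccc(-c5ccc(S(=O)(=O)N6CCOCC6)cc5)cc34)cc2Cl)c1` differs from compound 3 in one place, on a saturated chain carbon bound to an oxygen on an aromatic ring, where 3-methoxyphenyl stands in place of 2-fluorophenyl (3-methoxyphenyl in place of 2-fluorophenyl on a saturated chain carbon bound to an oxygen on an aromatic ring).

Three measured steps involve this same place. The closest comparison is a step that the two limits leave unreadable from compound 2 to compound 3, where one substituted phenyl group replaces another. The other two are a step that the two limits leave unreadable from compound 1 to compound 2 and a step that the two limits leave unreadable from compound 1 to compound 3. None of them has a readable size, so they offer no sign of a real change. No step beyond the usual scatter is expected in this assay, and no direction can be predicted. The expected change is a step that the limit leaves unreadable from compound 3 to compound 4. Most likely, this assay will again report only a limit for compound 4. As a number, compound 4 is estimated at 20000 nM, with an expected range from 10000 nM to 40000 nM.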

Compound 4, half-maximal inhibitory concentration: > 15000 nM
Compound 4: a limit, no number (the forecaster's own chance of this, stated with the estimate: 85%); the middle value does not contradict the limit.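

Compound 4 gives > 15000 nM in this assay as a limit of the assay, not a number. The steps joining compound 4 to compound 1, compound 2 and compound 3 therefore cannot be read, and all four compounds share one position: the limit of > 15000 nM in this assay, at which 4 of the 4 values shown sit.

The compounds shown leave open whether changing the group on this chain carbon alters cytotoxicity at all.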